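A few compounds are considered here, and "the series" means these few. Any claim that something is new, unique, unknown or untested is made for them only; others in the source may bear on it.

Measured compounds in an assay on cells for inhibition of Pendrin (Mus musculus), read by fluorescence, with a stated time of 10 min; a lower number here means a stronger inhibitor, a higher number a weaker inhibitor:
Compound 1 `Cn1nc(COc2cc(F)cc(F)c2)c2c1CCN(C(=O)Nc1ccc(Cl)cc1)C2` gives 3100 nM.
Compound 2 `CC(C)NC(=O)N1CCc2c(c(COc3cc(F)cc(F)c3)nn2C)C1` gives > 10000 nM, which is a limit of the assay and not a number.

Compound 2 thus stands at the weak end of the two values, with only the limit of > 10000 nM in this assay, at which 1 of the 2 values shown sits, known for it. Compound 3 `Cn1nc(COc2cc(F)cc(F)c2)c2c1CCN(C(=S)Nc1ccc(Cl)cc1)C2` has not yet been measured in this assay. It differs from compound 2 by a group of 10 heavy atoms (7 carbon, 1 nitrogen, 1 sulfur, 1 chlorine; one six-membered aromatic ring of carbon only) in place of a group of 6 heavy atoms (4 carbon, 1 nitrogen, 1 oxygen; no ring), on an amine nitrogen in a ring. Going by the values given here, one measured step bears on this change: an at least 3.2-fold higher number from compound 1 to compound 2 (0.50 log units; beyond the scatter), the reverse exchange of 4-chlorophenyl for isopropyl on the amide-type nitrogen. Among the compounds with values here, compound 3 brings the 4-chlorophenyl back but carries a thiocarbonyl where compound 1 carries a carbonyl, and no measured pair covers that exchange. Taking the measured step of an at least 3.2-fold higher number from compound 1 to compound 2 (0.50 log units; beyond the scatter) in reverse, the step from compound 2 to compound 3 is estimated as an at least 2.8-fold lower number from compound 2 to compound 3 (0.45 log units; beyond the scatter). Compound 3 is therefore expected near 3500 nM, within 1000 nM to 12000 nM.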

Compound 3, half-maximal inhibitory concentration: > 10000 nM
Compound 3: a limit, no number (the forecaster's own chance of this, stated with the estimate: 25%); middle value at least 2.8-fold (0.45 log units) from the limit.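

In this assay compound 3 gives > 10000 nM, a limit of the assay and not a number. The 4-chlorophenyl group alone therefore does not secure a measurable value on this amine nitrogen in a ring: exchanging the carbonyl for a thiocarbonyl gives an at least 3.2-fold higher number from compound 1 to compound 3 (0.50 log units; beyond the scatter), so the carbonyl matters here as well as the group on the amide-type nitrogen. The step between compound 2 and compound 3 cannot be read, because both ends are limits: the limit of > 10000 nM in this assay, at which 2 of the 3 values shown sit.

As far as these compounds go, how far compound 2 and compound 3 lie past the limit remains open, so the two cannot be ranked. Also open, from the compounds shown here alone, is whether a sulfonyl or a methylene link in place of the carbonyl, or a 4-methoxyphenyl or a carboxylic acid in place of the 4-chlorophenyl, would keep a measurable value.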